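The compounds below may be only part of what the source reports. "The series", "measured", "known", "first", "only" and "open" are said of these compounds alone.

Compound 1 `COc1cc(-c2nc(SCc3cn(CC(=O)NC(=O)Nc4ccccn4)nn3)nc(Nc3ccc(C(C)C)cc3)c2C#N)cc(OC)c1OC`: in a functional assay on ECa-109 cells (Homo sapiens) for inhibition, read by MTT assay, with a stated time of 72 h (on this read-out lower numbers stand for stronger inhibition and higher numbers for weaker inhibition), compound 1 gives > 64000 nM, a limit of the assay.
Compound 2 `Cc1ccc(-c2nc(SCc3cn(CC(=O)NC(=O)Nc4ccccn4)nn3)nc(Nc3ccc(C(C)C)cc3)c2C#N)cc1`: in this assay compound 2 gives 7450 nM.
Compound 3 `CC(C)c1ccc(Nc2nc(SCc3cn(CC(=O)NC(=O)Nc4ccccn4)nn3)nc(-c3ccc(Br)cc3)c2C#N)cc1`: in this assay compound 3 gives > 64000 nM, a limit of the assay.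

Compound 3 stands at the limit of the assay (the limit of > 64000 nM in this assay, at which 2 of the 3 values shown sit). Only compound 2 returned a number. The change to compound 4 `CC(C)c1ccc(Nc2nc(SCc3cn(CC(=O)NC(=O)Nc4ccccn4)nn3)nc(-c3ccc(Cl)cc3)c2C#N)cc1` is chloro in place of bromo on an aromatic carbon. The steps that reach compound 3 bear on it: an at least 8.5-fold higher number from compound 2 to compound 3 (0.93 log units; beyond the scatter), and a step that the two limits leave unreadable from compound 1 to compound 3. Neither involves chloro, so the halogen swap itself is not covered by a measured step, and compound 3 already sits at the limit. The expected step is an at least 1.2-fold lower number from compound 3 to compound 4 (0.10 log units; that floor lies within the scatter), most likely returning another limit. The expected value for compound 4 is 50000 nM, between 12000 nM and 150000 nM.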

Compound 4, half-maximal inhibitory concentration: > 64000 nM
Compound 4: a limit, no number; the forecaster's own chance of this, stated with the estimate: 60%; at least 1.2-fold (0.10 log units) between middle value and limit.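

Chloro, para to a large group, gives a limit of the assay and not a number, so compound 4 adds a second halogen to the bromo result, with the gap to methyl persisting: an at least 8.5-fold higher number from compound 2 to compound 4 (0.93 log units; beyond the scatter). The steps joining two limits cannot be read, so chloro, bromo and 3,4,5-trimethoxyphenyl cannot be ordered. Methyl remains the only group here to return a number, and the limit now holds most of the series: the limit of > 64000 nM in this assay, at which 3 of the 4 values shown sit.

Open, going by these compounds, is whether an amine or a longer alkyl chain in place of methyl would also return a number. Also open, on these data alone, is how far below the limit either halogen compound lies, if at all.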